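The compounds below may be only part of what the source reports. "The series", "measured", "known", "first", "only" and "open" are said of these compounds alone.

In a functional assay on cells (leukaemia cell line, Homo sapiens) for inhibition, read by sulforhodamine B assay, with a stated time of 48 h (a higher number here means a weaker inhibitor of growth, a lower number a stronger inhibitor of growth), compound 1 (`O=S(=O)(Nc1ccc(Cl)c(Cl)c1)c1ccc(-c2cnc(C3CC3)o2)cc1`) gives 416 nM, compound 2 (`O=S(=O)(Nc1ccc(Br)c(Cl)c1)c1ccc(-c2cnc(C3CC3)o2)cc1`) gives 491 nM and compound 3 (`Cc1ccc(NS(=O)(=O)c2ccc(-c3cnc(C4CC4)o3)cc2)cc1C`) gives 420 nM. Compound 3 therefore stands level with the other two, within the scatter of both. The next compound, compound 4 (`O=S(=O)(Nc1cc(F)cc(F)c1)c1ccc(-c2cnc(C3CC3)o2)cc1`), differs from it on a sulfonamide nitrogen, with 3,5-difluorophenyl in place of 3,4-dimethylphenyl on a sulfonamide nitrogen.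

The nearest evidence comes from earlier exchanges of the group at that nitrogen, which show a 1.0-fold higher number from compound 1 to compound 3 (0.00 log units; within the scatter) and a 1.2-fold lower number from compound 2 to compound 3 (0.07 log units; within the scatter). The bromo for chloro exchange shows a 1.2-fold higher number from compound 1 to compound 2 (0.07 log units; within the scatter). Going by the values given here, all three steps are small, but none of the measured compounds carries fluorine, so the data do not test this group directly. Among the compounds with values here, the expectation is therefore no step clearly beyond the scatter, with a slight lean towards a higher number. The expected change is a 1.5-fold higher number from compound 3 to compound 4 (0.19 log units; within the scatter). In this assay, the estimate for compound 4 is 650 nM, with an expected range from 280 nM to 1500 nM.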

Compound 4, concentration for 50% growth inhibition: 2140 nM
The estimate for compound 4 lay 3.3-fold (0.52 log units) below the measured number; the whole stated range lies below it.
By their numbers in this assay, from the lowest: compounds 1, 3 and 2 (each within the scatter of the next); then compound 4.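

Until compound 4, exchanges of the group on the sulfonamide nitrogen had produced no step beyond the scatter. In this assay the position proves sensitive to this change, with 3,5-difluorophenyl in place of 3,4-dimethylphenyl giving a clear step towards weaker growth inhibition (a 5.1-fold higher number from compound 3 to compound 4 (0.71 log units; beyond the scatter)). The comparisons with the two halogen-bearing compounds point the same way (a 4.4-fold higher number from compound 2 to compound 4 (0.64 log units; beyond the scatter) and a 5.1-fold higher number from compound 1 to compound 4 (0.71 log units; beyond the scatter)), so 3,5-difluorophenyl stands apart from 3,4-dimethylphenyl, 3,4-dichlorophenyl and 4-bromo-3-chlorophenyl, which remain level with one another. No measurement shown accounts for this difference.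

The compounds leave open whether the fluorines themselves or their placement sets compound 4 apart. They also leave open how an amine or a methoxy group on this aromatic ring would compare.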